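Long-chain esters of the shared core: cytotoxicity notes

A few compounds are considered here, and "the series" means these few. Any claim that something is new, unique, unknown or untested is made for them only; others in the source may bear on it.

Three long-chain esters of the shared core have been read so far: compound 1 `CCCCCCCCCCCC(=O)Oc1c(C(C)C)cc2c3c1OC(=O)[C@@]31CCCC(C)(C)[C@@H]1CC2`, compound 2 `CCCCCCCCCCCCCCCC(=O)Oc1c(C(C)C)cc2c3c1OC(=O)[C@@]31CCCC(C)(C)[C@@H]1CC2` and compound 3 `CCCCCCCC/C=C/CCCCCCCC(=O)Oc1c(C(C)C)cc2c3c1OC(=O)[C@@]31CCCC(C)(C)[C@@H]1CC2`. In an ADME assay on MRC5 cells (Homo sapiens) for cytotoxicity, read by neutral red uptake, with a stated time of 24 h (on this read-out lower numbers stand for stronger inhibition and higher numbers for weaker inhibition), compound 1 gives > 1000000 nM, which is a limit. Compound 2 gives > 1000000 nM, also a limit. Compound 3 gives > 1000000 nM, again a limit, so it stands without a number. Within the data shown here, the whole series so far rests on (the limit of > 1000000 nM in this assay, at which 3 of the 3 values shown sit).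

Compound 4 `CCCCC/C=C/C/C=C/CCCCCCCC(=O)Oc1c(C(C)C)cc2c3c1OC(=O)[C@@]31CCCC(C)(C)[C@@H]1CC2` differs from compound 3 only within the chain: hept-1-en-1-yl in place of heptyl on a saturated chain carbon bound to a double-bonded chain carbon. In words, this is hept-1-en-1-yl in place of heptyl on a saturated chain carbon bound to a double-bonded chain carbon.

The measured steps that bear on this change are the other chain changes: a step that the two limits leave unreadable from compound 1 to compound 2, a step that the two limits leave unreadable from compound 1 to compound 3 and a step that the two limits leave unreadable from compound 2 to compound 3. None of them gives a size, so this assay offers no measured effect of a chain change to carry over. The nearest reference is compound 3 at > 1000000 nM, a limit, so no step beyond the scatter is expected in either direction. The expected step is a number no higher from compound 3 to compound 4 (the limit leaves the size open). Compound 4 is estimated at 1000000 nM, within an expected range of 300000 nM to 3000000 nM, and will most likely be reported only as a limit.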

Compound 4, half-maximal inhibitory concentration: 293000 nM
Beside the measured number, compound 4's estimate is 3.4-fold (0.53 log units) above it, outside the stated range (below it).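

In this assay, among these compounds, compound 4 is the first ester of the shared core to return a number rather than a limit, so this position on the chain now shows a readable change: hept-1-en-1-yl in place of heptyl, on a saturated chain carbon bound to a double-bonded chain carbon, gives an at least 3.4-fold lower number from compound 3 to compound 4 (0.53 log units; beyond the scatter). Against the esters with fully saturated chains the picture is the same, with an at least 3.4-fold lower number from compound 2 to compound 4 (0.53 log units; beyond the scatter) and an at least 3.4-fold lower number from compound 1 to compound 4 (0.53 log units; beyond the scatter). The steps among compound 1, compound 2 and compound 3 cannot be read, and the three new steps fix only a lower bound on size, because the other esters all rest on a limit: the limit of > 1000000 nM in this assay, at which 3 of the 4 values shown sit.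

As far as these compounds go, whether the same change would lower the number on a longer chain, or with the double bonds set elsewhere along the chain, stays open, since a single compound carries this effect. Also open, from the compounds shown here alone, is what an amine or a carboxylic acid at the far end of the chain would do in this assay.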